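The compounds below may be only part of what the source reports. "The series", "measured", "known", "first", "only" and "open" are said of these compounds alone.

Measured so far in a functional assay on SK-BR-3 cells (Homo sapiens) for antiproliferative activity, read by MTT assay, with a stated time of 72 h; a lower number here means a stronger inhibitor, a higher number a weaker inhibitor:
compound 1 `C/C=C1/[C@H](O[C@@H]2O[C@H](CO)[C@@H](O)[C@H](O)[C@H]2O)OC=C(C(=O)OC)[C@H]1CC(=O)O` gives > 15000 nM, a limit of the assay.
compound 2 `C/C=C1/[C@H](O[C@@H]2O[C@H](COC(C)=O)[C@@H](OC(C)=O)[C@H](OC(C)=O)[C@H]2OC(C)=O)OC=C(C(=O)OC)[C@H]1CC(=O)OCCC1CCCCC1` gives > 15000 nM, a limit of the assay.
compound 3 `C/C=C1/[C@H](O[C@@H]2O[C@H](CO)[C@@H](O)[C@H](O)[C@H]2O)OC=C(C(=O)O)[C@H]1CC(=O)O` gives > 50000 nM, a limit of the assay.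

Compound 1 stands only at a limit in this assay; no number for it is known, and the two other values shown are limits as well. Within the data shown here, the single one-place step measured, a step that the two limits leave unreadable from compound 1 to compound 3, cannot be sized, since both of its ends sit at limits the limit of > 15000 nM in this assay, at which 2 of the 3 values shown sit, and (the limit of > 50000 nM in this assay, at which 1 of the 3 values shown sits). Among the measured compounds shown here, compound 2, which carries acetyl groups on the sugar and a different ester on the same acid, also sits at a limit, and no one-place step links it to compound 1.

Compound 4 `C/C=C1/[C@H](O[C@@H]2O[C@H](CO)[C@@H](O)[C@H](O)[C@H]2O)OC=C(C(=O)OC)[C@H]1CC(=O)OCCc1ccc([N+](=O)[O-])cc1` is the unmeasured ester: 2-(4-nitrophenyl)ethyl in place of hydrogen on an oxygen next to a carbonyl group. For the measured compounds named here, no measured step bears on this change; the only step available is unreadable. The step that the limit leaves unreadable from compound 1 to compound 4 is therefore expected to be small, with compound 4 remaining near the limits seen so far. Compound 4 is estimated at 20000 nM, between 5000 nM and 60000 nM, most likely again reported only as a limit.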

Compound 4, half-maximal inhibitory concentration: > 20000 nM
Compound 4 ended at the assay's limit; the forecaster's own chance of this, stated with the estimate: 65%; the middle value sits exactly at the limit.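

In this assay compound 4 gives > 20000 nM, a limit of the assay. Compound 1 also stands only at a limit, so the step to compound 4 cannot be read. Still open, from the compounds shown here alone, is whether any ester of the core of compound 1 gives a number rather than a limit in this assay.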